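The compounds below may be only part of what the source reports. "The series", "measured", "known", "first", "only" and "open" are said of these compounds alone.

Measured compounds in a functional assay on NCI-H661 cells (Homo sapiens) for cytotoxicity, read by WST assay, with a stated time of 72 h; a higher number here means a weaker inhibitor, a lower number a stronger inhibitor:
compound 1, `CCN(CC)CCCOc1cc2ncnc(Nc3nc4ccc(C(=O)Nc5c(C)cccc5C)cc4s3)c2cc1OC`: 66500 nM
compound 2, `COc1cc2c(Nc3nc4ccc(C(=O)Nc5c(C)cccc5Cl)cc4s3)ncnc2cc1OCCCN1CCC(C)CC1`: 7900 nM
compound 3, `COc1cc2c(Nc3nc4ccc(C(=O)Nc5c(C)cccc5C)cc4s3)ncnc2cc1OCCCN1CCCCC1`: only the assay's limit, > 100000 nM

Compound 3 therefore stands at the weak end of the three: its result in this assay is a limit and not a number, so its true value is not known. For the measured compounds named here, the one measured step that reaches it, an at least 1.5-fold higher number from compound 1 to compound 3 (0.17 log units; that floor lies within the scatter), has its floor within the scatter, and since the value of compound 3 is itself the limit (the limit of > 100000 nM in this assay, at which 1 of the 3 values shown sits), the size of that step is open at the top. Compound 2, with chloro in place of one methyl and a methylpiperidinyl ring, gives a number rather than a limit, but no single-step comparison to compound 3 is available.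

Compound 4, `COc1cc2c(Nc3nc4ccc(C(=O)Nc5c(C)cc(C)cc5C)cc4s3)ncnc2cc1OCCCN1CCCCC1`, differs from compound 3 in one place: methyl in place of hydrogen on an aromatic carbon. Going by the values given here, none of the measured steps touches this position, so no step bears directly on it; the only guide is the standing of compound 3 at the limit. Compound 4 is expected to stay near that limit, with a number no higher from compound 3 to compound 4 (the limit leaves the size open) amounting to no change beyond the scatter. The estimate for compound 4 in this assay is 100000 nM, between 30000 nM and 300000 nM, with a real chance that only a limit is reported again.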

Compound 4, half-maximal inhibitory concentration: 10000 nM
The estimate for compound 4 lay 10-fold (1.00 log units) above the measured number; the measured number lies below the stated range.
By their numbers in this assay, from the lowest: compounds 2 and 4 (each within the scatter of the next); then compound 1. At a limit, above all of these: compound 3.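

In this assay, for the compounds shown here, methyl in place of hydrogen on the aromatic carbon para to a large group gives an at least 10-fold lower number from compound 3 to compound 4 (1.00 log units; beyond the scatter), so this position, which no earlier step touched, does register in the read-out. The entering group is a single methyl with no ring, no hydrogen-bond donor or acceptor and no net charge, and the rest of the structure stays the same, so even this small change on the 2,6-dimethylphenyl ring is enough to turn a result without a number into a measured one. The step gives only a floor and not a full size, because compound 3 stands at a limit of the assay and not at a number: the limit of > 100000 nM in this assay, at which 1 of the 4 values shown sits.

The compounds shown leave open whether a methoxy group, a chloro group, an amine or a longer alkyl chain on this same carbon would act as methyl does here. They also leave open whether the 2,4,6-trimethylphenyl group would bring a similar change alongside the diethylamino chain of compound 1 or the methylpiperidinyl ring of compound 2.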